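One More Methoxy Group on Compound 2

This account rests on a few compounds, and the source may have more. Where it says the series, first, only, none or still open, it means among the compounds named here.

Compound 1 `COc1cc(-c2cc(/C=C/C(=O)c3ccc(N)cc3)[nH]n2)cc(OC)c1OC` and compound 2 `COc1ccc(C(=O)/C=C/c2cc(-c3cc(OC)c(OC)c(OC)c3)n[nH]2)cc1OC` share one core and differ only in the group on the carbonyl carbon. In a functional assay on A549 cells (Homo sapiens) for inhibition, read by sulforhodamine B assay, with a stated time of 48 h (on this read-out lower numbers stand for stronger inhibition of growth and higher numbers for weaker inhibition of growth), compound 1 gives 7020 nM, and compound 2 gives 4590 nM; the swap gives a 1.5-fold lower number from compound 1 to compound 2 (0.18 log units; within the scatter), so compound 2 holds the lowest of the two numbers shown, with its gap to compound 1 inside the scatter. Compound 3 `COc1cc(C(=O)/C=C/c2cc(-c3cc(OC)c(OC)c(OC)c3)n[nH]2)cc(OC)c1OC` carries methoxy in place of hydrogen on an aromatic carbon. For the measured compounds named here, only that single small step bears on this change, so no step beyond the scatter is expected, and compound 3 is estimated at 4000 nM, between 1500 nM and 11000 nM, meaning a 1.1-fold lower number from compound 2 to compound 3 (0.06 log units; within the scatter).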

Compound 3, concentration for total growth inhibition: 12100 nM
Estimate against measurement, compound 3: 3.0-fold (0.48 log units) below; measured number above the stated range.
By their numbers in this assay, from the lowest: compounds 2, 1 and 3 (each within the scatter of the next, the first and the last beyond it).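

In this assay, methoxy in place of hydrogen on this aromatic carbon, ortho to a methoxy group and meta to a large group, gives a 2.6-fold higher number from compound 2 to compound 3 (0.42 log units; beyond the scatter) and thus weaker inhibition of growth. This is the only step shown that lies beyond the scatter, so this position does respond to a change. No available evidence accounts for the step.

From the compounds shown here alone, whether this response is specific to methoxy remains open. A fluorine atom, a hydroxyl group or an amine at the same carbon could settle that question.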